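A few compounds are considered here, and "the series" means these few. Any claim that something is new, unique, unknown or untested is made for them only; others in the source may bear on it.

Compound 1 `CC(=O)c1ccc2[nH]c(-c3ccc(Cl)cc3)nc2c1`: > 100000 nM
Compound 2 `CC(=O)c1ccc2[nH]c(-c3ccc(C(F)(F)F)cc3)nc2c1`: > 100000 nM
Compound 3 `COc1ccc(-c2nc3cc(C(C)=O)ccc3[nH]2)c(OC)c1OC`: > 100000 nM

In an ADME assay on BHK-21 cells (Mesocricetus auratus) for cytotoxicity, read by MTT assay (on this read-out higher numbers stand for lower toxicity in this test and lower numbers for higher toxicity in this test), compound 1 gives > 100000 nM, which is a limit of the assay and not a number. The same holds across the set: the limit of > 100000 nM in this assay, at which 3 of the 3 values shown sit. Compound 1 therefore has no exact position, and no order can be read among the three compounds.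

Compound 4 `C/C(=N\O)c1ccc2[nH]c(-c3ccc(Cl)cc3)nc2c1` keeps the core of compound 1. The change is a group of 4 heavy atoms (2 carbon, 1 nitrogen, 1 oxygen; no ring) in place of a group of 3 heavy atoms (2 carbon, 1 oxygen; no ring), on an aromatic carbon: a group of 4 heavy atoms in place of acetyl, on an aromatic carbon.

Going by the values given here, the only measured step is a step that the two limits leave unreadable from compound 1 to compound 2. It concerns trifluoromethyl in place of chloro, not the acetyl group, and gives no size to carry over. Among the compounds with values here, no measured compound shows what replacing acetyl does, so a fall in this assay cannot be ruled out. With compound 1 at > 100000 nM, however, no shift beyond the scatter is expected.

The expected change is a number no higher from compound 1 to compound 4 (the limit leaves the size open).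

For compound 4 the estimate is 100000 nM, with an expected range of 30000 nM to 200000 nM.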

Compound 4, half-maximal cytotoxic concentration: 33000 nM
Beside the measured number, compound 4's estimate is 3.0-fold (0.48 log units) above it, within the range that was stated.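

In this assay, going by these compounds alone, this position turns out to be sensitive: the replacement of acetyl on this aromatic carbon gives an at least 3.0-fold lower number from compound 1 to compound 4 (0.48 log units; beyond the scatter), the first change that moves a value off the assay limit. Compound 1 gives > 100000 nM, which is a limit and not a number, so the step has a lower bound but no exact size. Compound 4, at 33000 nM, is the only compound here with a readable number: the limit of > 100000 nM in this assay, at which 3 of the 4 values shown sit.

The change is shown only with the chloro substituent of compound 1, so whether it would carry over to the trifluoromethyl of compound 2 or the aryl group of compound 3 stays open. As far as these compounds go, how an amine or a carboxylic acid on this aromatic carbon would read in this assay also stays open.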